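A few compounds are considered here, and "the series" means these few. Any claim that something is new, unique, unknown or untested is made for them only; others in the source may bear on it.

Three compounds have been measured in a functional assay on HL-60 cells (Homo sapiens) for inhibition, read by MTT assay, with a stated time of 72 h, tested at 50 uM; on this read-out lower numbers stand for less inhibition of growth and higher numbers for more inhibition of growth at the one concentration tested:

Compound 1 `C=CCc1ccc(OCc2cn(-c3ccccc3CO)nn2)c(O)c1`: 47.1%
Compound 2 `C=CCc1ccc(OCc2cn(-c3cc(OC)c(OC)c(OC)c3)nn2)c(O)c1`: 41.4%
Compound 3 `C#CCOc1ccc(CC=C)cc1O`: 34.2%

Compound 1 stands highest of the three numbers. Compound 2 comes nearest to it, and the gap between the two lies within the usual scatter, so they cannot be told apart. Compound 3 lies furthest away, with a number lower than that of compound 1 by a gap beyond the scatter.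

Compound 4 `C=CCc1ccc(OCc2cn(-c3cccc(C#N)c3)nn2)c(O)c1` has not yet been measured. It differs from compound 1 in one place: 3-cyanophenyl in place of 2-(hydroxymethyl)phenyl on an aromatic nitrogen. Going by the values given here, no measured pair shows the effect of such a swap, so the size of this step is uncertain. The nearest guide is compound 2, which carries a different group on the same aromatic nitrogen and gives 41.4%, a number that cannot be told apart from compound 1. A small step is therefore expected, a number 4.1 percentage points lower from compound 1 to compound 4 (within the scatter), none beyond the scatter. Compound 4 is expected to give 43%, within a range from 30% to 56%.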

Compound 4, percent growth inhibition at one concentration: 30.9%
The estimate for compound 4 lay 12.1 percentage points above the measured number, within the range that was stated.
By their numbers in this assay, from the lowest: compounds 4, 3, 2 and 1 (each within the scatter of the next, the first and the last beyond it).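

In this assay, the group on the aromatic nitrogen of the five-membered ring proves able to shift the result: 3-cyanophenyl in place of 2-(hydroxymethyl)phenyl gives a number 16.2 percentage points lower from compound 1 to compound 4 (beyond the scatter) on the shared core. The earlier compounds shown here could not show this, as no measured pair differed in this one place. The position is therefore not indifferent to what it carries, although this rests on a single step of modest size.

On these data alone, the swap changes two things at once, taking away the hydroxymethyl and bringing in the nitrile, and how the step divides between them stays open, as does how a plain phenyl or an aminomethylphenyl would compare. Nothing measured here explains the step.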